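From pentyl to 4-methoxyphenyl on a shared core

A few compounds are considered here, and "the series" means these few. Any claim that something is new, unique, unknown or untested is made for them only; others in the source may bear on it.

Compound 1 `CCCCCn1ccnc1-c1cc(OC)c(OC)c(OC)c1` gives 57900 nM 
Compound 2 `COc1cc(-c2nccn2S(=O)(=O)c2ccc(C)cc2)cc(OC)c1OC` gives > 100000 nM 

Only two results exist so far, both from one kind of experiment. Going by the values given here, in a functional assay on MDA-MB-468 cells (Homo sapiens) for antiproliferative activity, read by MTT assay, with a stated time of 72 h (a higher number here means a weaker inhibitor, a lower number a stronger inhibitor), compound 1 gives 57900 nM as the only actual number available, so it has no measured neighbour to be ranked against.

Compound 2 reads > 100000 nM here, and that is a limit of the assay, not a number.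

Compound 3 `COc1ccc(-n2ccnc2-c2cc(OC)c(OC)c(OC)c2)cc1` keeps the rest of compound 1 but carries 4-methoxyphenyl in place of pentyl on an aromatic nitrogen, a change counted in full as 4-methoxyphenyl in place of pentyl on an aromatic nitrogen in the comparison of the two structures.

Among the compounds with values here, no measured pair shows what such a swap does, so any forecast is rough. Compound 1 at 57900 nM sits high on the scale of this assay and leaves much room downward, so a clear step toward a stronger inhibitor, beyond the scatter, is expected rather than no change. The estimate amounts to an expected 12-fold lower number from compound 1 to compound 3 (1.06 log units; beyond the scatter) overall, with real uncertainty on its size.

Compound 3 is expected at 5000 nM (estimated range 300 nM to 50000 nM).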

Compound 3, half-maximal inhibitory concentration: 500 nM
Beside the measured number, compound 3's estimate is 10-fold (1.00 log units) above it; the range from low to high includes it.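

In this assay, going by these compounds alone, putting 4-methoxyphenyl in place of pentyl on an aromatic nitrogen gives a 120-fold lower number from compound 1 to compound 3 (2.06 log units; beyond the scatter) and provides the first comparison here between two compounds that differ in one place. It shows that antiproliferative activity in these cells depends strongly on the group at this position, since the step lies well beyond the usual scatter, but the change is not a single simple one: a chain with no ring gives way to a group with a six-membered aromatic ring, an oxygen and a hydrogen-bond acceptor. The results shown establish the size of the step but offer no measured reason for it.

Within the data shown here, the single pair cannot separate the contribution of the aromatic ring from that of its methoxy group, and a plain phenyl group would be needed to pull those two apart. Going by these compounds, how a benzyl group, a hydroxyphenyl group or a shorter chain such as ethyl would behave on this nitrogen also remains open, so no trend across this position can yet be drawn.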